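Aryl in place of amino on the carbonyl of compound 2

The source may report more compounds than this note shows. Statements on the series, on what has been measured and on what is new or still open speak of the compounds shown alone.

Among the measured compounds shown here, compound 2 `N#C/C(=C\N1CCN(C(=O)c2ccco2)C1=S)C(N)=O` gives 22500 nM in a functional assay on BT-549 cells (Homo sapiens) for inhibition, read by sulforhodamine B assay, with a stated time of 48 h (on this read-out lower numbers stand for stronger inhibition of growth and higher numbers for weaker inhibition of growth), and stands at the higher end of the two numbers so far, with compound 1 `N#C/C(=C\N1CCN(C(=O)c2ccco2)C1=S)C(=O)Nc1ccc(Cl)cc1` at 8600 nM the nearest and lower. The measured step from compound 1 to compound 2, a 2.6-fold higher number from compound 1 to compound 2 (0.42 log units; beyond the scatter), is the only one that bears on the next change; it shows that removing an aryl group from the amide-type nitrogen weakened growth inhibition by a modest amount. Compound 3 `N#C/C(=C\N1CCN(C(=O)c2ccco2)C1=S)C(=O)c1ccccc1` differs from compound 2 by phenyl in place of amino on a carbonyl carbon, a carbamoyl to benzoyl change. Since the return of an aryl group in compound 1 runs with the lower number 8600 nM, a modest fall in this assay is expected, not more than the reverse of that step. Compound 3 is therefore estimated at 8000 nM, between 3000 nM and 20000 nM, meaning an expected step of a 2.8-fold lower number from compound 2 to compound 3 (0.45 log units; beyond the scatter).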

Compound 3, concentration for 50% growth inhibition: 7800 nM
Beside the measured number, compound 3's estimate is 1.0-fold (0.01 log units) above it, within the range that was stated.
By their numbers in this assay, from the lowest: compounds 3 and 1 (each within the scatter of the next); then compound 2.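

In this assay, phenyl in place of amino on a carbonyl carbon, the carbamoyl to benzoyl change, gives a 2.9-fold lower number from compound 2 to compound 3 (0.46 log units; beyond the scatter), so an aryl group joined directly to that carbonyl carbon goes with the same modest shift as the aryl group carried on the amide-type nitrogen of compound 1. Phenyl in place of (4-chlorophenyl)amino gives a 1.1-fold lower number from compound 1 to compound 3 (0.04 log units; within the scatter), within the scatter, so the two aryl-bearing compounds stand level. In this assay, neither the amide-type nitrogen nor the chlorine is needed to hold that level, though the two were changed together and cannot be told apart here.

From the compounds shown here alone, whether an aryl ring is needed at all stays open, and cyclohexyl, methyl or 4-chlorophenyl on the same carbonyl carbon would address this. No independent measurement accounts for the shift seen with the aryl groups.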